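Swapping trifluoromethyl for fluoro on the benzyl ring

The source may report more compounds than this note shows. Statements on the series, on what has been measured and on what is new or still open speak of the compounds shown alone.

The compounds here share one core, seen in compound 2 `O=C(O)c1ccc(Cl)cc1-c1ccc2c(c1)OC[C@H](Cc1ccc(C(F)(F)F)cc1)[C@H]2O` and compound 3 `O=C(O)c1ccc(F)cc1-c1ccc2c(c1)OC[C@H](Cc1ccc(C(F)(F)F)cc1)[C@H]2O`. In a functional assay with leukotriene B4 receptor (Homo sapiens) as the target (a lower number here means a stronger inhibitor, a higher number a weaker inhibitor), compound 2 gives 9000 nM, the highest of the two single numbers, and compound 3 gives 1800 nM. Going by the values given here, the only measured step is a 5.0-fold lower number from compound 2 to compound 3 (0.70 log units; beyond the scatter). Compound 1 `O=C(O)c1c(F)cccc1-c1ccc2c(c1)OC[C@H](Cc1ccccc1)[C@H]2O` has several entries rather than a single number, namely 10 nM; 40 nM; 650 nM (3 entries).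

Compound 4 `O=C(O)c1ccc(Cl)cc1-c1ccc2c(c1)OC[C@H](Cc1ccc(F)cc1)[C@H]2O` differs from compound 2 by fluoro in place of trifluoromethyl on an aromatic carbon. Among the compounds with values here, no measured step covers this change: the step from compound 2 to compound 3 touches a different ring. Of the compounds without trifluoromethyl, compound 1 shows lower numbers than compound 3, which carries trifluoromethyl, but these two also differ elsewhere, so this is a hint and not a rule.

Compound 4 is therefore expected to give 3000 nM, between 800 nM and 12000 nM, which means an estimated step of a 3.0-fold lower number from compound 2 to compound 4 (0.48 log units; beyond the scatter).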

Compound 4, half-maximal inhibitory concentration: 400 nM
Compound 4: middle estimate off by 7.5-fold (0.88 log units), on the high side, outside the stated range (below it).
By their numbers in this assay, from the lowest: compound 4; then compound 3; then compound 2.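

In this assay the swap from trifluoromethyl to fluoro on the benzyl ring gives a 23-fold lower number from compound 2 to compound 4 (1.35 log units; beyond the scatter) and so shows that the number responds strongly to the group at this position. The earlier step on the other ring, a 5.0-fold lower number from compound 2 to compound 3 (0.70 log units; beyond the scatter) and rated modest, is the smaller of the two, so the benzyl ring position matters at least as much as the position on that other ring. Going by these compounds alone, this single pair gives the size of the swap but not the reason for it, and it was seen only with chloro on the other ring.

From the compounds shown here alone, whether the swap gives a similar step with fluoro on the other ring stays open, as does the effect of a methoxy group, an amine or a carboxylic acid at this position. Compound 1, with no group on its benzyl ring, cannot settle this, since it also differs on the other ring and its values spread widely: the several entries of compound 1 in this assay, 10 nM; 40 nM; 650 nM (3 entries)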